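Lengthening the ether chain of compound 2

The compounds below may be only part of what the source reports. "The series", "measured", "known", "first", "only" and "open" are said of these compounds alone.

Within the data shown here, in an ADME assay on HCT-116 cells (Homo sapiens) for antiproliferative activity (on this read-out lower numbers stand for stronger inhibition and higher numbers for weaker inhibition), compound 2 (`CCOc1ccc(C(N)=O)cc1/C=C/c1ccc(Cl)cc1`) gives 1700 nM and holds the lower of the two numbers so far. Compound 1 (`COc1ccc(C(N)=O)cc1/C=C/c1ccc(C(F)(F)F)cc1`) gives 35000 nM and differs from compound 2 in more than one place. Compound 3 (`NC(=O)c1ccc(OCCOCCO)c(/C=C/c2ccc(Cl)cc2)c1`) follows from compound 2 through one change (2-hydroxyethoxy in place of hydrogen on a saturated chain carbon, two bonds along the chain from an oxygen on an aromatic ring), with 2-hydroxyethoxy in place of hydrogen on a saturated chain carbon. Among the measured compounds shown here, no measured pair covers this change. A small rise in the number is expected in this assay and the estimated step (a 1.8-fold higher number from compound 2 to compound 3 (0.25 log units; within the scatter)) stays close to the scatter. Compound 3 is estimated at 3000 nM with a range from 800 nM to 12000 nM for this series.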

Compound 3, half-maximal inhibitory concentration: 38000 nM
Compound 3: the middle estimate sits 13-fold (1.10 log units) below what was measured, outside the stated range (above it).
By their numbers in this assay, from the lowest: compound 2; then compounds 1 and 3 (each within the scatter of the next).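

In this assay, among these compounds, the ethoxy chain of compound 2 proves sensitive to extension: 2-(2-hydroxyethoxy)ethoxy in place of ethoxy gives a 22-fold higher number from compound 2 to compound 3 (1.35 log units; beyond the scatter) and this is the first single-place step. It marks this chain position as one where added length with a terminal hydroxyl weakens inhibition, on this one pair only. No measurement at hand accounts for the size of this step.

As far as these compounds go, whether the chain length or the terminal hydroxyl carries the loss remains open. A plain propyl or butyl ether, a 2-methoxyethoxy chain, or a terminal amine on the same chain would bear on that question.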